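The source may report more compounds than this note shows. Statements on the series, on what has been measured and on what is new or still open speak of the compounds shown alone.

Compound 1 `CCCN(CCC)c1ccc(Nc2ncc(Cl)c(Oc3cccc(NC(=O)CC)c3)n2)cc1`, compound 2 `CCC(=O)Nc1cccc(Oc2nc(Nc3ccc(N4CCN(C)CC4)cc3)ncc2Cl)c1` and compound 3 `CCC(=O)Nc1cccc(Oc2nc(Nc3ccc(N4CCC(OC)CC4)cc3OC)ncc2Cl)c1` share one core and differ in the groups carried on the aniline ring. In an assay on isolated protein for inhibition of NUAK family SNF1-like kinase 1 (Homo sapiens), read by ADP-Glo, with a stated time of 60 min, tested at 10 uM, in the presence of a further agent that is not named here (a lower number here means less inhibition, a higher number more inhibition at the concentration tested (going by the name of the read-out)), compound 1 gives 9.3%, compound 2 gives 92.9% and compound 3 gives 5.08%. Compound 3 thus holds the smallest of the three numbers, although its value and that of compound 1 lie within the scatter of each other, while compound 2 stands far beyond both. For the measured compounds named here, the only step measured in one place is a number 83.6 percentage points higher from compound 1 to compound 2 (beyond the scatter), a swap of one amine for another. Compound 4 `CCC(=O)Nc1cccc(Oc2nc(Nc3ccc(N4CCC(OC)CC4)cc3)ncc2Cl)c1` differs from compound 3 by hydrogen in place of methoxy on an aromatic carbon. Going by the values given here, no measured step touches this change: the single known step concerns the amine and not the methoxy, so its large size offers no guide to what removing the methoxy will do in this assay. With nothing in the shown compounds pointing to a gain, compound 4 is expected to remain close to compound 3, and the estimated step is a number 4.9 percentage points higher from compound 3 to compound 4 (within the scatter). In this assay compound 4 is accordingly estimated at 10%, with a range from 0% to 35%.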

Compound 4, a percentage reported as inhibition, at one concentration (the size of the read-out at that concentration, not a potency): 86.5%
Beside the measured number, compound 4's estimate is 76.5 percentage points below it, and the stated range ends below it.
By their numbers in this assay, from the lowest: compounds 3 and 1 (each within the scatter of the next); then compounds 4 and 2 (each within the scatter of the next).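

In this assay, the step of a number 81.4 percentage points higher from compound 3 to compound 4 (beyond the scatter) shows that the aromatic carbon ortho to a large group and meta to the 4-methoxypiperidin-1-yl group can matter on its own, since exchanging methoxy for hydrogen there gives a large step with the amine unchanged. The low number of compound 3 therefore goes with the methoxy and not with the 4-methoxypiperidin-1-yl group, which, with hydrogen at that carbon, gives a step of a number 6.4 percentage points lower from compound 2 to compound 4 (within the scatter) against 4-methylpiperazin-1-yl and a large step of a number 77.2 percentage points higher from compound 1 to compound 4 (beyond the scatter) against dipropylamino, so the high numbers are not tied to the 4-methylpiperazin-1-yl group alone. Nothing at hand explains why the methoxy has this effect.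

The compounds shown leave open whether a fluorine, a methyl or an ethoxy group on the same carbon would go with a number near that of compound 3 or near that of compound 4. They also leave open whether the methoxy would go with the same large step when the amine is 4-methylpiperazin-1-yl or dipropylamino, since it appears here with the 4-methoxypiperidin-1-yl group only.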